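The compounds below may be only part of what the source reports. "The series", "measured", "known", "first", "only" and "open" are said of these compounds alone.

Measured compounds:
compound 1, `O=C(COc1ccc2cc(/C=C3/SC(=O)NC3=O)ccc2c1)Nc1ccccc1`, 2100 nM
compound 2, `COc1ccc(NC(=O)COc2ccc3cc(/C=C4/SC(=O)NC4=O)ccc3c2)cc1`, 4700 nM

Both values come from an assay on isolated protein for inhibition of histone deacetylase 4 (Homo sapiens), with a stated time of 1 h; a higher number here means a weaker inhibitor, a lower number a stronger inhibitor. Of the two numbers shown, compound 2 stands at the higher, weaker end: its only neighbour is compound 1, and the step of a 2.2-fold higher number from compound 1 to compound 2 (0.35 log units; beyond the scatter) is a modest loss of potency that lies beyond the scatter. Within the data shown here, that step is the sole measured change in this small set, and it concerns a different group than the one now considered.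

Compound 3, `O=C(COc1ccc2cc(/C=C3/SC(=O)NC3=O)ccc2c1)Nc1ccc(Br)cc1`, differs from compound 2 by bromo in place of methoxy on an aromatic carbon. No measured step here swaps one group for another at that position; the only step shown, a 2.2-fold higher number from compound 1 to compound 2 (0.35 log units; beyond the scatter), tells how adding methoxy to hydrogen affected the number, not how bromo compares with methoxy. With so little to lean on, the expectation for compound 3 in this assay is a number near the two measured ones, most likely a small change as a 1.6-fold lower number from compound 2 to compound 3 (0.19 log units; within the scatter), estimated at 3000 nM with a range from 1200 nM to 7500 nM.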

Compound 3, half-maximal inhibitory concentration: 2900 nM
Compound 3: the middle estimate sits 1.0-fold (0.01 log units) above what was measured; the range from low to high includes it.
By their numbers in this assay, from the lowest: compounds 1, 3 and 2 (each within the scatter of the next, the first and the last beyond it).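

In this assay, bromo in place of methoxy gives a step that lies within the scatter (a 1.6-fold lower number from compound 2 to compound 3 (0.21 log units; within the scatter)), and so does bromo in place of hydrogen (a 1.4-fold higher number from compound 1 to compound 3 (0.14 log units; within the scatter)). Compound 3 therefore cannot be told apart from either of its two neighbours, even though those neighbours differ from each other by more than the scatter, so this position accepts a bromo with no readable effect on the number. Nothing here offers an explanation for these numbers.

From the compounds shown here alone, whether any group at this position can move the number well beyond the scatter remains open, for example an amine or a carboxylic acid. Going by these compounds, it is also open whether a longer chain in place of the methoxy would give a larger step than bromo does.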